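This account rests on a few compounds, and the source may have more. Where it says the series, first, only, none or still open, it means among the compounds named here.

Of the compounds shown here, two that share one core have been measured in an assay on isolated protein for inhibition of Aromatase (Homo sapiens), read by ELISA, using NADPH, with a stated time of 24 h; a lower number here means a stronger inhibitor, a higher number a weaker inhibitor. Compound 1 `Fc1ccc2c(Cn3ccnc3)c(-c3ccc(Cl)cc3)[nH]c2c1` gives 82.9 nM in this assay, and compound 2 `COc1ccc(-c2[nH]c3cc(F)ccc3c2Cn2ccnc2)cc1` gives 36.1 nM. Of these two numbers compound 1 stands highest. Among the measured compounds shown here, the one measured step, a 2.3-fold lower number from compound 1 to compound 2 (0.36 log units; beyond the scatter), arises from a methoxy in place of a chloro on an aromatic carbon, a change at the far end of the molecule.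

Compound 3 `Fc1ccc2c(Cn3cncn3)c(-c3ccc(Cl)cc3)[nH]c2c1` has not yet been measured. It differs from compound 1 by 1H-1,2,4-triazol-1-yl in place of 1H-imidazol-1-yl on a saturated chain carbon bound to an aromatic carbon. For the measured compounds named here, no measured step bears on this change: the single step available alters a different part of the molecule and says nothing about swapping the five-membered ring on the saturated chain carbon. With no guide in the data, the expectation for compound 3 is a number close to that of compound 1, with any shift expected to be small, in either direction. Compound 3 is therefore estimated at 110 nM in this assay, with a likely range from 40 nM to 300 nM. That estimate amounts to an expected step of a 1.3-fold higher number from compound 1 to compound 3 (0.12 log units; within the scatter).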

Compound 3, half-maximal inhibitory concentration: 217 nM
For compound 3 the middle estimate is 2.0-fold (0.30 log units) below the measured one; the range from low to high includes it.
By their numbers in this assay, from the lowest: compound 2; then compound 1; then compound 3.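

Among the compounds shown here, this is the first measured change at the saturated chain carbon, a part of the molecule that the swap of chloro for methoxy left untouched. In this assay, 1H-1,2,4-triazol-1-yl in place of 1H-imidazol-1-yl gives a 2.6-fold higher number from compound 1 to compound 3 (0.42 log units; beyond the scatter), so inhibition responds to the identity of this ring, even though both rings have five heavy atoms and carry no net charge, and the entering ring differs by holding more nitrogen and more hydrogen-bond acceptors. No measurement shown here accounts for this weaker inhibition.

For the compounds shown here, these compounds do not show whether the effect of the methoxy swap would carry over to a compound bearing the 1H-1,2,4-triazol-1-yl group, since each change has been seen only on its own. Nor do they show how inhibition would respond to a different group on the saturated chain carbon, such as an amine, a carboxylic acid or a longer chain carrying the ring.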